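A Thiophen-2-yl Step from Compound 2 to Compound 4

The source may report more compounds than this note shows. Statements on the series, on what has been measured and on what is new or still open speak of the compounds shown alone.

Three measured compounds share a core carrying two amide groups. Compound 1 `C=Cc1cccc(C(=O)N2CCCC(C(=O)Nc3ccc(Cl)cc3)C2)c1`, compound 2 `CSc1cccc(C(=O)N2CCCC(C(=O)Nc3ccc(Cl)cc3)C2)c1` and compound 3 `C=CCOc1cccc(NC(=O)C2CCCN(C(=O)c3cc(C(F)(F)F)cc(C(F)(F)F)c3)C2)c1` were all tested in an ADME assay on PC-3 cells (Homo sapiens) for cytotoxicity, read by WST assay, tested at 100 uM; a lower number here means less inhibition, a higher number more inhibition at the concentration tested (going by the name of the read-out). There compound 1 gives 0%, compound 2 gives 0% and compound 3 gives 0%. Going by the values given here, the one step between close neighbours, no change at the digits printed from compound 1 to compound 2 (within the scatter), leaves the read-out unchanged within the scatter. Compound 2 thus stands level with compound 1 and with compound 3 at the digits shown; its nearest neighbour is compound 1 and its furthest is compound 3, and neither pair differs beyond the scatter.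

Compound 4 `O=C(Nc1ccc(Cl)cc1)C1CCCN(C(=O)c2cccc(-c3cccs3)c2)C1` has not yet been measured. It differs from compound 2 as follows: thiophen-2-yl in place of methylsulfanyl on an aromatic carbon. Among the compounds with values here, the only step that bears directly on this change is no change at the digits printed from compound 1 to compound 2 (within the scatter), which was flat, and the larger exchange of aryl groups between compound 2 and compound 3 also left the value unchanged within the scatter. A flat step is therefore expected, no change at the digits printed from compound 2 to compound 4 (within the scatter), with no direction beyond the scatter. For compound 4 in this assay the estimate is 0%, with a range from 0% to 15%.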

Compound 4, a percentage reported as inhibition, at one concentration (the size of the read-out at that concentration, not a potency): 4%
Estimate against measurement, compound 4: 4 percentage points below, within the range that was stated.
By their numbers in this assay, from the lowest: compounds 1, 2, 3 and 4 (each within the scatter of the next).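

In this assay, going by these compounds alone, the place on the six-membered aromatic ring of carbon only, meta to a large group, now carries a ring for the first time: thiophen-2-yl, with one five-membered aromatic ring and 5 heavy atoms, replaces methylsulfanyl, which has 2 heavy atoms and no ring, and this gives a number 4 percentage points higher from compound 2 to compound 4 (within the scatter). Set against vinyl at the same place, the thiophen-2-yl group gives a number 4 percentage points higher from compound 1 to compound 4 (within the scatter), so the three groups tested at this place, with and without a ring, stay within the scatter of one another. No measurement is available that explains this result.

Since these steps all lie within the scatter, the compounds shown do not identify any group at this place that separates one compound from another in this assay. Going by these compounds, it remains open whether an amine, a carboxylic acid or a longer alkyl chain at this place would give a step beyond the scatter, and compound 3 differs from the others in more than one place, so it cannot settle what a single change elsewhere on the shared core would do.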